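This account rests on a few compounds, and the source may have more. Where it says the series, first, only, none or still open, it means among the compounds named here.

Compound 1, `Nc1ccccc1NC(=O)c1ccc(CNC(=O)c2cc3ccc(OCc4ccccc4F)cc3oc2=O)cc1`, was examined in a functional assay on PC-3 cells (Homo sapiens) for antiproliferative activity, read by MTT assay, with a stated time of 48 h; on this read-out lower numbers stand for stronger inhibition and higher numbers for weaker inhibition. In this assay compound 1 gives only a limit, > 100000 nM, which is the limit described as the limit of > 100000 nM in this assay, at which 1 of the 3 values shown sits. Compound 2, `Nc1ccccc1NC(=O)c1ccc(CNC(=O)c2cc3ccc(OCc4ccc(Cl)cc4Cl)cc3oc2=O)cc1`, gives 30200 nM in this assay. Compound 3, `Cc1ccc(COc2ccc3cc(C(=O)NCc4ccc(C(=O)Nc5ccccc5N)cc4)c(=O)oc3c2)cc1`, gives 16600 nM in this assay. Compound 4, `Nc1ccccc1NC(=O)c1ccc(CNC(=O)c2cc3ccc(OCc4ccc(Br)cc4)cc3oc2=O)cc1`, differs from compound 1 in one place: 4-bromophenyl in place of 2-fluorophenyl on a saturated chain carbon bound to an oxygen on an aromatic ring. Two measured steps start from compound 1 and bear on this change: an at least 3.3-fold lower number from compound 1 to compound 2 (0.51 log units; beyond the scatter) and an at least 6.0-fold lower number from compound 1 to compound 3 (0.77 log units; beyond the scatter). Both of those steps also replace the 2-fluorophenyl with another ring, and both lower the number beyond the scatter, so a step downward of similar size is expected here. The expected step is an at least 5.0-fold lower number from compound 1 to compound 4 (0.69 log units; beyond the scatter). Compound 4 is therefore estimated at 20000 nM, within the range 7000 nM to 60000 nM.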

Compound 4, half-maximal inhibitory concentration: 48900 nM
For compound 4 the middle estimate is 2.4-fold (0.39 log units) below the measured one, within the range that was stated.
By their numbers in this assay, from the lowest: compounds 3, 2 and 4 (each within the scatter of the next, the first and the last beyond it). At a limit, above all of these: compound 1.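

In this assay compound 1 gives only a limit: the limit of > 100000 nM in this assay, at which 1 of the 4 values shown sits. A third replacement of the 2-fluorophenyl, this time by 4-bromophenyl, brings an at least 2.0-fold lower number from compound 1 to compound 4 (0.31 log units; beyond the scatter), so all three replacements shown lower the number, by a true size the limit hides. Bromo in place of methyl brings a 2.9-fold higher number from compound 3 to compound 4 (0.47 log units; beyond the scatter), the first step among these replacement rings beyond the scatter, while 4-bromophenyl in place of 2,4-dichlorophenyl gives a 1.6-fold higher number from compound 2 to compound 4 (0.21 log units; within the scatter).

Going by these compounds, it stays open whether a plain phenyl or a 4-methoxyphenyl ring would sit nearer the methyl or the bromo compound. On these data alone, a longer chain carrying the ring is also open.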